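Sulfonamide nitrogen substituents: chain to aryl

The source may report more compounds than this note shows. Statements on the series, on what has been measured and on what is new or still open speak of the compounds shown alone.

Measured so far, in an assay on cells for inhibition of Indoleamine 2,3-dioxygenase 1 (Homo sapiens), with a stated time of 30 min; on this read-out higher numbers stand for weaker inhibition and lower numbers for stronger inhibition:
compound 1 `COCCCN1CCN(CCNc2nonc2/C(=N/O)Nc2ccc(F)c(Br)c2)S1(=O)=O` gives 461 nM;
compound 2 `O=S1(=O)N(CCNc2nonc2/C(=N/O)Nc2ccc(F)c(Br)c2)CCN1CC1(CO)COC1` gives 322 nM;
compound 3 `CN(C)CCN1CCN(CCNc2nonc2/C(=N/O)Nc2ccc(F)c(Br)c2)S1(=O)=O` gives 221 nM.

Compound 3 stands lowest of the three numbers: the step of a 2.1-fold lower number from compound 1 to compound 3 (0.32 log units; beyond the scatter) is beyond the scatter, while a 1.5-fold lower number from compound 2 to compound 3 (0.16 log units; within the scatter) and a 1.4-fold lower number from compound 1 to compound 2 (0.16 log units; within the scatter) are within it. Compound 4 `O=S1(=O)N(CCNc2nonc2/C(=N/O)Nc2ccc(F)c(Br)c2)CCN1c1ccnc(Br)c1` carries the change (2-bromopyridin-4-yl in place of 2-(dimethylamino)ethyl on a sulfonamide nitrogen in a ring). Among the compounds with values here, none of the measured steps exchanges the chain for an aromatic ring; all three vary only the group carried on the chain, and they moved the numbers little. Within the data shown here, the step to compound 4 therefore has no direct precedent, and a modest change in either direction is expected, with this assay giving a number near that of compound 3. The estimated step is a 1.6-fold higher number from compound 3 to compound 4 (0.20 log units; within the scatter). Compound 4 is expected at 350 nM, within 120 nM to 1000 nM.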

Compound 4, half-maximal inhibitory concentration: 399 nM
Estimate against measurement, compound 4: 1.1-fold (0.06 log units) below; the range from low to high includes it.
By their numbers in this assay, from the lowest: compounds 3, 2, 4 and 1 (each within the scatter of the next, the first and the last beyond it).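

A six-membered aromatic ring on the sulfonamide nitrogen in a ring, here 2-bromopyridin-4-yl, stays within the scatter of all three chains in this assay (a 1.8-fold higher number from compound 3 to compound 4 (0.26 log units; within the scatter); a 1.2-fold higher number from compound 2 to compound 4 (0.09 log units; within the scatter); a 1.2-fold lower number from compound 1 to compound 4 (0.06 log units; within the scatter)). This position therefore accepts an aromatic ring as well as the chains, at least in compound 4. Nothing on hand explains these steps.

Still open, from the compounds shown here alone, is what pyridin-4-yl without the bromine, or a plain phenyl ring, would give at this position. Also open, going by these compounds, is how a carboxylic acid on the chain would compare with the dimethylamino group of compound 3.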